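This account rests on a few compounds, and the source may have more. Where it says the series, first, only, none or still open, it means among the compounds named here.

Compound 2 (`CC(C)N(Cc1cccc(OCCCCCC(=O)O)c1)C(=O)c1ccc(-c2cccc(Br)c2)cc1`) was tested in an ADME assay on HepG2 cells (Homo sapiens) for cytotoxicity, read by CellTiter-Glo and resazurin assay, with a stated time of 72 h; a higher number here means that more compound is needed for the effect, a lower number that less compound is needed. In this assay compound 2 gives only a limit, > 26000 nM. Compound 1 (`CC(C)N(Cc1cccc(OCCCCCC(=O)O)c1)C(=O)c1ccc(-c2ccc3[nH]ccc3c2)cc1`) likewise gives only a limit in this assay, > 26000 nM. Going by the values given here, the single measured step, a step that the two limits leave unreadable from compound 1 to compound 2, cannot be sized because both values sit at the limit of > 26000 nM in this assay, at which 2 of the 2 values shown sit. Compound 3 (`CC(C)N(Cc1cccc(OCCCCCC(=O)O)c1)C(=O)c1ccc(-c2cccc([N+](=O)[O-])c2)cc1`) carries nitro in place of bromo on an aromatic carbon. Among the compounds with values here, no measured step involves a nitro group, so nothing beyond the scatter is expected: a step that the limit leaves unreadable from compound 2 to compound 3. Compound 3 is therefore estimated at 40000 nM in this assay, within a range from 15000 nM to 120000 nM, and most probably again reported only as a limit.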

Compound 3, half-maximal effective concentration: > 26000 nM
Compound 3: no number, only a limit; the forecaster's own chance of this, stated with the estimate: 80%; the middle value does not contradict the limit.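

Going by these compounds alone, no step among compound 1, compound 2 and compound 3 can be read, as all three values are limits and not numbers: the limit of > 26000 nM in this assay, at which 3 of the 3 values shown sit. Going by these compounds, whether the 1H-indol-5-yl, 3-bromophenyl and 3-nitrophenyl groups differ at all in this assay stays open.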